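The source may report more compounds than this note shows. Statements on the series, on what has been measured and on what is new or still open speak of the compounds shown alone.

In a functional assay on DLD-1 cells (Homo sapiens) for antiproliferative activity, read by CellTiter-Glo, with a stated time of 72 h (a lower number here means a stronger inhibitor, a higher number a weaker inhibitor), compound 1 (`COc1ccccc1-c1cccc(S(=O)(=O)N2CCC(N3CCC(C)CC3)CC2)c1`) stands at 21 nM within the scatter of compound 2 (`COc1ccccc1-c1ccc(S(=O)(=O)N2CCC(N3CCC(C)CC3)CC2)cc1`) at 26 nM while compound 3 (`CC1CCN(C2CCN(S(=O)(=O)c3ccc(-c4ccccc4F)cc3)CC2)CC1`) gives a lower number at 5 nM beyond the scatter from both. The change followed here leads from compound 1 to compound 4 (`CC1CCN(C2CCN(S(=O)(=O)c3cccc(-c4ccc(Cl)cc4)c3)CC2)CC1`). In it, 4-chlorophenyl takes the place of 2-methoxyphenyl on an aromatic carbon, meta to a large group (4-chlorophenyl in place of 2-methoxyphenyl on an aromatic carbon).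

Within the data shown here, only one measured step bears on this change. Fluoro in place of methoxy on an aromatic carbon gave a 5.2-fold lower number from compound 2 to compound 3 (0.72 log units; beyond the scatter) and this modest step lies beyond the scatter. It too removes a methoxy group, but it starts from compound 2 and brings in fluoro, not 4-chlorophenyl. Among the measured compounds shown here, no measured step shows what 4-chlorophenyl does, so it is only a partial guide. A shift in the same direction is therefore expected, though smaller and within the scatter. The expected move is a 1.8-fold lower number from compound 1 to compound 4 (0.24 log units; within the scatter) and it remains an uncertain estimate. Compound 4 is expected at 12 nM within an estimated range of 4 nM to 40 nM in this assay.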

Compound 4, half-maximal inhibitory concentration: 15 nM
Estimate against measurement, compound 4: 1.3-fold (0.10 log units) below, and the stated range covers the measured number.
By their numbers in this assay, from the lowest: compound 3; then compounds 4, 1 and 2 (each within the scatter of the next).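

In this assay, the step to 4-chlorophenyl on this aromatic carbon, meta to a large group, is a 1.4-fold lower number from compound 1 to compound 4 (0.15 log units; within the scatter), so compound 4 cannot be told apart from compound 1. The 2-methoxyphenyl group, with its hydrogen-bond acceptor, can thus give way here to a group with none and with chlorine in its ring substitution, without a change beyond the scatter, whereas the earlier step that removed a methoxy group, a 5.2-fold lower number from compound 2 to compound 3 (0.72 log units; beyond the scatter), lay beyond it. No measured evidence bears on why this replacement leaves the number within the scatter.

The compounds shown leave open whether the chlorine matters at all, as this step changes both the substituent and its place on the phenyl ring, and no compound separates the two or shows the unsubstituted phenyl group on this carbon. From the compounds shown here alone, it also remains open how this carbon would respond to a phenyl ring bearing an amine or a carboxylic acid in place of the chlorine, and whether the 2-fluorophenyl group of compound 3 would give a lower number here as well.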